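This account rests on a few compounds, and the source may have more. Where it says the series, first, only, none or still open, it means among the compounds named here.

Measured so far in a functional assay on HeLa cells (Homo sapiens) for cytotoxicity, read by ELISA, with a stated time of 2 days; a lower number here means a stronger inhibitor, a higher number a weaker inhibitor:
- compound 1 `Oc1cccc(-c2cc(-c3ccccc3)cc(-c3cccc(O)c3)n2)c1` gives 13000 nM
- compound 2 `Oc1ccccc1-c1cc(-c2ccccc2)nc(-c2ccco2)c1` gives 9700 nM
- compound 3 `Oc1cccc(-c2cc(-c3ccccc3)nc(-c3cccs3)c2)c1` gives 15300 nM

Compound 3 stands level with the other two, as all three values lie within the usual scatter of one another. In compound 4 `Oc1cccc(-c2cc(-c3ccccc3)nc(-c3ccncc3)c2)c1` pyridin-4-yl takes the place of thiophen-2-yl on an aromatic carbon next to the ring nitrogen pyridin-4-yl in place of thiophen-2-yl on an aromatic carbon of the shared core. For the measured compounds named here, no measured pair isolates a single change. Compound 3 at 15300 nM and compound 2 at 9700 nM carry different groups without a gap beyond the scatter, so no step beyond the scatter is expected in this assay here. The expected change, a 1.3-fold lower number from compound 3 to compound 4 (0.11 log units; within the scatter), is small and has no firm direction. For compound 4 the estimated value is 12000 nM, with an expected range of 5000 nM to 30000 nM.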

Compound 4, half-maximal inhibitory concentration: 15000 nM
The estimate for compound 4 lay 1.3-fold (0.10 log units) below the measured number; low and high end bracket the measured number.
By their numbers in this assay, from the lowest: compounds 2, 1, 4 and 3 (each within the scatter of the next).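

In this assay the first pair differing in one place shows a 1.0-fold lower number from compound 3 to compound 4 (0.01 log units; within the scatter) at this aromatic carbon next to the ring nitrogen, so pyridin-4-yl and thiophen-2-yl are not told apart there. A six-membered aromatic ring can stand in for a five-membered one, each with one hetero atom, with the number staying within the scatter. Nothing measured here gives a cause for this.

Open, as far as these compounds go, is whether a non-aromatic group at this carbon, such as an amine or a carboxylic acid, would give a step beyond the scatter.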